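Acetyl in place of methylsulfonyl on an amine nitrogen

The source may hold more compounds than are shown below. What is called first, only, known or untested is meant among the compounds shown, and "the series" means these compounds.

Measured so far in a functional assay on OVCAR-8 cells (Homo sapiens) for antiproliferative activity; a lower number here means a stronger inhibitor, a higher number a weaker inhibitor
compound 1 `Cn1ncc(Cl)c1-c1cc(C(=O)N[C@@H]2CN[C@H](CCNS(C)(=O)=O)C[C@H]2c2ccc(F)c(F)c2)oc1Cl` at 1530 nM
compound 2 `Cn1ncc(Cl)c1-c1cc(C(=O)N[C@@H]2CN[C@H](CCCO)C[C@H]2c2ccc(Cl)c(Cl)c2)oc1Cl` at 600 nM
compound 3 `Cn1ncc(Cl)c1-c1cc(C(=O)N[C@@H]2CN[C@H](CCn3cncn3)C[C@H]2c2ccc(Cl)c(Cl)c2)oc1Cl` at 1560 nM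
Not yet measured
compound 4 `CC(=O)NCC[C@@H]1C[C@@H](c2ccc(F)c(F)c2)[C@H](NC(=O)c2cc(-c3c(Cl)cnn3C)c(Cl)o2)CN1`

Compound 1 at 1530 nM lies within the scatter of compound 3 at 1560 nM and compound 2 at 600 nM gives a lower number than both. Compound 4 differs from compound 1 by acetyl in place of methylsulfonyl on an amine nitrogen and the rest of the structure is shared. Within the data shown here, the one measured step of a 2.6-fold higher number from compound 2 to compound 3 (0.41 log units; beyond the scatter) is modest and concerns other groups, so it suggests a size but no direction. The estimated change a 1.1-fold lower number from compound 1 to compound 4 (0.04 log units; within the scatter) is small, and no step beyond the scatter is expected. In this assay compound 4 is estimated at 1400 nM with 600 nM to 3200 nM as its expected range.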

Compound 4, half-maximal inhibitory concentration: 880 nM
Estimate against measurement, compound 4: 1.6-fold (0.20 log units) above; the measured number falls inside the stated range.
By their numbers in this assay, from the lowest: compounds 2, 4, 1 and 3 (each within the scatter of the next, the first and the last beyond it).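

In this assay, acetyl in place of methylsulfonyl on an amine nitrogen gives a 1.7-fold lower number from compound 1 to compound 4 (0.24 log units; within the scatter). Among these compounds, this is the first step read at this nitrogen, and it does not separate the two groups: the 2-acetamidoethyl and 2-(methanesulfonamido)ethyl chains cannot be ranked here. No measured data on hand explain the result.
Compound 2 and compound 3 differ from compound 4 in more than one place, so they do not extend this comparison. Open, going by these compounds, is whether a urea, a free amine or a longer chain at this position would give a step beyond the scatter.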